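Chloro-to-hydrogen step carried across two cores

The source may hold more compounds than are shown below. What is called first, only, known or untested is meant among the compounds shown, and "the series" means these compounds.

Of the compounds shown here, three have been measured in a functional assay on the whole organism with Mus musculus as the target; on this read-out lower numbers stand for an effect already at smaller amounts and higher numbers for an effect only at larger amounts of compound. Compound 1 `Cc1nnc(CNC(=O)CN)n1-c1ccc(Cl)cc1C(=O)c1ccccc1` gives 0.72 mg/kg. Compound 2 `CN(C(=O)CNC(=O)CN)c1ccc(Cl)cc1C(=O)c1ccccc1Cl` gives 0.8 mg/kg, and compound 3 `Cc1nnc(CNC(=O)CN)n1-c1ccc(Cl)cc1C(=O)c1ccccc1Cl` gives 0.27 mg/kg. Compound 1 and compound 3 share one core and differ only by hydrogen in place of chloro on an aromatic carbon; this change gave a 2.7-fold higher number from compound 3 to compound 1 (0.43 log units; beyond the scatter). Compound 2 carries a different core, and the difference between the two cores is not broken down here. Against compound 1, compound 2 shows a number within the scatter, while against compound 3 it shows a clearly higher one.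

Compound 4 `CN(C(=O)CNC(=O)CN)c1ccc(Cl)cc1C(=O)c1ccccc1` has not yet been measured. It arises from compound 2 by hydrogen in place of chloro on an aromatic carbon, the same change that turns compound 3 into compound 1, at the same kind of place in both pairs. Going by the values given here, only one measured pair shows the effect of this change, so the expectation rests on that pair alone. If the step carries from one core to the other, compound 4 should show a number higher than compound 2 by about the same amount. The expected step from compound 2 to compound 4 in this assay is a 2.5-fold higher number from compound 2 to compound 4 (0.40 log units; beyond the scatter), resting on a 2.7-fold higher number from compound 3 to compound 1 (0.43 log units; beyond the scatter). Compound 4 is therefore estimated at 2 mg/kg, with a range from 1 mg/kg to 4.5 mg/kg that allows for imperfect transfer of the step between the two cores.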

Compound 4, dose for half-maximal effect: 5.2 mg/kg
The estimate for compound 4 lay 2.6-fold (0.41 log units) below the measured number, and the stated range ends below it.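

In this assay the change from 2-chlorophenyl to phenyl gives a 6.5-fold higher number from compound 2 to compound 4 (0.81 log units; beyond the scatter) and so runs the same way as on the core of compound 1, with the chloro compound giving the lower number on both cores. This shows that the direction of the step held on the two cores available, but two pairs do not establish a fixed size for it, do not explain why removing chloro has this outcome, and say nothing about any further core in the series. The sizes on the two cores cannot be told apart, so a single shared step remains compatible with both pairs, while a real difference between the cores is not excluded either: the same change on two cores in this assay, a 2.7-fold higher number (0.43 log units; beyond the scatter) from compound 3 to compound 1 and a 6.5-fold higher number (0.81 log units; beyond the scatter) from compound 2 to compound 4, 2.4-fold (0.39 log units) apart, within the scatter of two such steps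

The compounds shown leave open whether fluoro, bromo, methyl or methoxy at the same aromatic carbon would stay closer to chloro or to hydrogen on either core. They also leave open how the step behaves when the chloro on the other aromatic ring, present in all four compounds, gives way to hydrogen or fluoro, or when the terminal amine is carried on a longer chain.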